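Swapping a carbamate for a bromopyridine ether on the side chain

The compounds below may be only part of what the source reports. "The series", "measured", "known", "first", "only" and "open" are said of these compounds alone.

The compounds here share one core and differ only in the group carried on the oxygen of the side chain. Compound 1, `COc1nc(C)c(Nc2nc(Cl)cn([C@H](COC(=O)Nc3ccccc3)C3CC3)c2=O)cc1C`, gives 1.5 nM in an assay on frontal cortex for displacement of a labelled ligand from corticotropin-releasing factor receptor 1 (Rattus norvegicus), with a stated time of 2 h; on this read-out higher numbers stand for weaker inhibition and lower numbers for stronger inhibition. Compound 2, `COc1nc(C)c(Nc2nc(Cl)cn([C@H](COC(=O)Nc3ccc(Cl)cc3)C3CC3)c2=O)cc1C`, gives 1.6 nM in this assay, and compound 3, `CCNC(=O)OC[C@H](C1CC1)n1cc(Cl)nc(Nc2cc(C)c(OC)nc2C)c1=O`, gives 14 nM. Among these three numbers compound 2 holds the second highest, with compound 1 nearest at a 1.1-fold higher number from compound 1 to compound 2 (0.03 log units; within the scatter), and compound 3 furthest at an 8.8-fold higher number from compound 2 to compound 3 (0.94 log units; beyond the scatter).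

Compound 4, `COc1nc(C)c(Nc2nc(Cl)cn([C@H](COc3cc(Br)ccn3)C3CC3)c2=O)cc1C`, has not yet been measured. It differs from compound 2 by 4-bromopyridin-2-yl in place of (4-chlorophenyl)carbamoyl on an oxygen on a saturated carbon. Among the measured compounds shown here, no measured step makes this same change. The nearest guides are an 8.8-fold higher number from compound 2 to compound 3 (0.94 log units; beyond the scatter) and a 9.3-fold higher number from compound 1 to compound 3 (0.97 log units; beyond the scatter), which show that trading an aromatic ring for ethyl on the amide-type nitrogen costs a modest amount, while a 1.1-fold higher number from compound 1 to compound 2 (0.03 log units; within the scatter) shows that a chloro on that ring changes little. Compound 4 keeps an aromatic ring but drops the carbamoyl link, so a step of modest size toward a higher number, or none beyond the scatter, is expected. The estimate for compound 4 in this assay is 3 nM, with a range from 0.8 nM to 12 nM, meaning an expected 1.9-fold higher number from compound 2 to compound 4 (0.27 log units; within the scatter).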

Compound 4, half-maximal inhibitory concentration: 1.5 nM
The estimate for compound 4 lay 2.0-fold (0.30 log units) above the measured number, within the range that was stated.
By their numbers in this assay, from the lowest: compounds 1, 4 and 2 (each within the scatter of the next); then compound 3.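

In this assay, the whole (4-chlorophenyl)carbamoyl group on this oxygen can be replaced by 4-bromopyridin-2-yl with a 1.1-fold lower number from compound 2 to compound 4 (0.03 log units; within the scatter), and the same holds for replacing phenylcarbamoyl, with no change at the digits printed from compound 1 to compound 4 (within the scatter). The earlier compounds shown here only varied what sat on the amide-type nitrogen, whereas this result shows that, at least with this aromatic ring, neither the carbonyl nor the amide hydrogen of the carbamate is required to reach these numbers. The ethylcarbamoyl group stands apart, with a 9.3-fold lower number from compound 3 to compound 4 (0.97 log units; beyond the scatter), so keeping the carbamate does not by itself give these numbers, but nothing shown here explains why such different groups read alike.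

Going by these compounds, the new group differs from the old ones in its link, its ring nitrogen and its bromine all at once, so the contribution of each remains unknown, and a plain phenyl ether or an unsubstituted pyridin-2-yl ether would help separate them. On these data alone, whether an aromatic ring is needed on this oxygen at all also remains open, a question that a simple ethyl ether or a longer saturated chain would address.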